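From compound 2 to compound 3: one aryl group exchanged

The source may hold more compounds than are shown below. What is called first, only, known or untested is meant among the compounds shown, and "the series" means these compounds.

Compound 1 `C#Cc1cccc(Nc2nc(Cl)nc3cc(OC)c(OC)cc23)c1`: 7500 nM
Compound 2 `COc1cc2nc(Cl)nc(Nc3cc(C)ccc3F)c2cc1OC`: > 40000 nM

In a functional assay on SK-HEP1 cells (Homo sapiens) for cytotoxicity, read by MTT assay, with a stated time of 48 h (on this read-out lower numbers stand for stronger inhibition and higher numbers for weaker inhibition), compound 2 gives > 40000 nM, which is a limit of the assay and not a number. Among the measured compounds shown here, the only measured step, an at least 5.3-fold higher number from compound 1 to compound 2 (0.72 log units; beyond the scatter), shows that the aryl group on that nitrogen can move the read-out well beyond the scatter, with one value at the limit of > 40000 nM in this assay, at which 1 of the 2 values shown sits. Compound 3 `COc1cc2nc(Cl)nc(Nc3ccc(O)c(C)c3)c2cc1OC` differs from compound 2 by 4-hydroxy-3-methylphenyl in place of 2-fluoro-5-methylphenyl on a nitrogen on an aromatic ring. For the measured compounds named here, no measured step covers this exchange, so no direction can be read from the data. Compound 3 is expected at 30000 nM, within 8000 nM to 80000 nM. This estimate means an expected at least 1.3-fold lower number from compound 2 to compound 3 (0.12 log units; that floor lies within the scatter).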

Compound 3, half-maximal inhibitory concentration: > 40000 nM
Compound 3: a limit, no number; the forecaster's own chance of this, stated with the estimate: 50%; middle value at least 1.3-fold (0.12 log units) away from the limit.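

In this assay compound 3 gives > 40000 nM, a limit of the assay and not a number, and the step from compound 2 cannot be read. Exchanging the 3-ethynylphenyl group for 4-hydroxy-3-methylphenyl gives an at least 5.3-fold higher number from compound 1 to compound 3 (0.72 log units; beyond the scatter), so an aryl group with a hydrogen-bond donor on that nitrogen also yields no number. Compound 1 remains the only one of the three with a number: the limit of > 40000 nM in this assay, at which 2 of the 3 values shown sit.

The compounds shown leave open whether a phenyl group bearing an amine or a carboxylic acid on that nitrogen would give a number, and whether the ethynyl group itself accounts for the value of compound 1.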